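The compounds below may be only part of what the source reports. "The series", "measured", "known", "first", "only" and "open" are said of these compounds alone.

In a functional assay on HL-60 cells (Homo sapiens) for antiproliferative activity, read by XTT assay, with a stated time of 72 h (a lower number here means a stronger inhibitor, a higher number a weaker inhibitor), compound 1 `COc1ncnc2c1c(-c1ccoc1)cn2[C@@H]1O[C@H](CO)[C@@H](O)[C@H]1O` gives 150 nM and compound 2 `CN(C)c1ncnc2c1c(-c1ccoc1)cn2[C@@H]1O[C@H](CO)[C@@H](O)[C@H]1O` gives 1160 nM. The difference between them is methoxy in place of dimethylamino on an aromatic carbon and it made a 7.7-fold lower number from compound 2 to compound 1 (0.89 log units; beyond the scatter). Compound 3 `CN(C)c1ncnc2c1c(-c1cc3ccccc3o1)cn2[C@@H]1O[C@H](CO)[C@@H](O)[C@H]1O` differs from compound 2 by 1-benzofuran-2-yl in place of furan-3-yl on an aromatic carbon, and in this assay that change made an at least 17-fold higher number from compound 2 to compound 3 (1.23 log units; beyond the scatter). For compound 3 the result in this assay is only a limit, > 20000 nM, which is the limit of > 20000 nM in this assay, at which 1 of the 3 values shown sits.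

Compound 4 `COc1ncnc2c1c(-c1cc3ccccc3o1)cn2[C@@H]1O[C@H](CO)[C@@H](O)[C@H]1O` has not been measured yet. It differs from compound 3 by methoxy in place of dimethylamino on an aromatic carbon, the same change that led from compound 2 to compound 1. Since the step from compound 2 to compound 1 was a 7.7-fold lower number from compound 2 to compound 1 (0.89 log units; beyond the scatter), compound 4 is expected to move by about an at least 3.3-fold lower number from compound 3 to compound 4 (0.52 log units; beyond the scatter) in this assay. Because compound 3 sits at the limit of > 20000 nM in this assay, at which 1 of the 3 values shown sits, the starting point for this step is itself uncertain, so the expectation stays broad and a limit remains possible. In this assay compound 4 is estimated at 6000 nM, with a range from 1500 nM to 30000 nM.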

Compound 4, half-maximal inhibitory concentration: 4470 nM
For compound 4 the middle estimate is 1.3-fold (0.13 log units) above the measured one; measured number inside the range.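

In this assay, methoxy in place of dimethylamino on the core carrying 1-benzofuran-2-yl gave an at least 4.4-fold lower number from compound 3 to compound 4 (0.65 log units; beyond the scatter), the same direction as on the core carrying furan-3-yl: the same change on two cores in this assay, a 7.7-fold lower number (0.89 log units; beyond the scatter) from compound 2 to compound 1 and an at least 4.4-fold lower number (0.65 log units; beyond the scatter) from compound 3 to compound 4; the limit leaves it open whether they differ

With methoxy on the core, 1-benzofuran-2-yl in place of furan-3-yl gave a 30-fold higher number from compound 1 to compound 4 (1.47 log units; beyond the scatter), again the direction seen with dimethylamino: the same change on two cores in this assay, an at least 17-fold higher number (1.23 log units; beyond the scatter) from compound 2 to compound 3 and a 30-fold higher number (1.47 log units; beyond the scatter) from compound 1 to compound 4; the limit leaves it open whether they differ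

Both changes therefore kept their direction across these two pairs, but the result for compound 3 is only a limit, > 20000 nM, so the data do not show that the size of either step carries over from one core to the other.

The compounds shown leave open whether the same direction would hold for other groups in place of methoxy and dimethylamino, such as ethoxy or a primary amine, or for other aromatic groups in place of furan-3-yl, such as furan-2-yl or phenyl. As far as these compounds go, all four compounds are also compared only in this assay, so whether these steps hold in other cells remains open.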